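Amino Added to the Chloropurine Core

A few compounds are considered here, and "the series" means these few. Any claim that something is new, unique, unknown or untested is made for them only; others in the source may bear on it.

Measured compounds:
compound 1 `CC(=O)OCCOCn1cc(/C=C/Br)c(=O)[nH]c1=O` — in a functional assay on L1210 cells (Mus musculus) for inhibition (a lower number here means a stronger inhibitor, a higher number a weaker inhibitor), compound 1 gives > 1000 ug/mL, which is a limit of the assay rather than a number.
compound 2 `OCCOCn1cnc2c(O)ncnc21` — compound 2 gives > 1000 ug/mL, again a limit of the assay.
compound 3 `CC(=O)OCCOCn1cnc2c(Cl)ncnc21` — compound 3 gives 44 ug/mL.

Among the compounds with values here, of the three results, only compound 3 carries an actual number; the other two sit at the limit of > 1000 ug/mL in this assay, at which 2 of the 3 values shown sit, so compound 3 is the single compound here that can be placed on the scale, with nothing measured above or below it to compare against. Compound 4 `CC(=O)OCCOCn1cnc2c(Cl)nc(N)nc21` is built from compound 3 by a change in one place: amino in place of hydrogen on an aromatic carbon. Within the data shown here, no two measured compounds differ in a single place, so there is no measured step to guide the size of this one. The change adds a small group to the fused core, and compound 4 is expected to stay close to compound 3, so that the step of a 1.4-fold higher number from compound 3 to compound 4 (0.13 log units; within the scatter) is expected to be modest, probably within the scatter or only slightly beyond it in either direction. Compound 4 is therefore estimated at 60 ug/mL, with a range from 10 ug/mL to 400 ug/mL.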

Compound 4, concentration for 50% inhibition: 91 ug/mL
Compound 4: middle estimate off by 1.5-fold (0.18 log units), on the low side, and the stated range covers the measured number.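

In this assay, within the data shown here, this is the first step that can be read at all: amino in place of hydrogen on an aromatic carbon, between two ring nitrogen atoms, gives a 2.1-fold higher number from compound 3 to compound 4 (0.32 log units; beyond the scatter). The step lies just beyond the scatter, so the amino compound is a modestly weaker inhibitor, yet it still gives a real number and not a limit, which shows that this carbon can carry the amino group without inhibition being lost. The earlier compounds could not show this, as none of them differ in a single place and two of them give only a limit: the limit of > 1000 ug/mL in this assay, at which 2 of the 4 values shown sit.

A single step at one carbon cannot show whether a methyl group, a hydroxyl group or a dimethylamino group there would behave like amino. It also leaves open why the number rises, and whether amino would have the same effect with the chloro group replaced by another group, such as a methoxy group.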